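The source may report more compounds than this note shows. Statements on the series, on what has been measured and on what is new or still open speak of the compounds shown alone.

Measured so far in an ADME assay (liver) for metabolic stability, with Liver microsome (Homo sapiens) as the target, using microsomes and NADPH, with a stated time of 30 min, tested at 1 uM; on this read-out higher numbers stand for fast clearance and lower numbers for slow clearance:
Compound 1 `Nc1ccc(S(=O)(=O)N2CCN(c3ncc(C(O)(C(F)(F)F)C(F)(F)F)cc3Br)CC2)cn1`: < 14 mL.min-1.g-1, a limit and not a number.
Compound 2 `COc1cc(C(O)(C(F)(F)F)C(F)(F)F)cnc1N1CCN(S(=O)(=O)c2ccc(N)nc2)CC1`: < 14 mL.min-1.g-1, a limit and not a number.
Compound 3 `Nc1ccc(S(=O)(=O)N2CCN(c3ncc(C(O)(C(F)(F)F)C(F)(F)F)cc3-c3cnccc3F)CC2)cn1`: 17 mL.min-1.g-1.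

Among the compounds with values here, compound 3 holds the only true number in this small set. The other two compounds share one reading, (the limit of < 14 mL.min-1.g-1 in this assay, at which 2 of the 3 values shown sit).

Compound 4 `Nc1ccc(S(=O)(=O)N2CCN(c3ncc(C(O)(C(F)(F)F)C(F)(F)F)cc3-c3ccc4sccc4c3)CC2)cn1` departs from compound 3 at a single place: 1-benzothiophen-5-yl in place of 4-fluoropyridin-3-yl on an aromatic carbon. In words, 1-benzothiophen-5-yl stands in place of 4-fluoropyridin-3-yl on an aromatic carbon.

Within the data shown here, two measured steps touch this same place. They are an at least 1.2-fold higher number from compound 1 to compound 3 (0.08 log units; that floor lies within the scatter) and an at least 1.2-fold higher number from compound 2 to compound 3 (0.08 log units; that floor lies within the scatter). Both are floors and not full sizes, and both bring in 4-fluoropyridin-3-yl, in place of bromo or methoxy. The step that the two limits leave unreadable from compound 1 to compound 2 adds nothing that can be read. Among the measured compounds shown here, no measured compound carries 1-benzothiophen-5-yl, so the data give only a weak guide to this step.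

Taking compound 3 at 17 mL.min-1.g-1 as the sole numerical anchor, a modest move towards faster clearance in this assay is expected, with real uncertainty. The expected change is a 2.1-fold higher number from compound 3 to compound 4 (0.31 log units; beyond the scatter).

For compound 4 the estimate is 35 mL.min-1.g-1, with an expected range from 15 mL.min-1.g-1 to 90 mL.min-1.g-1.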

Compound 4, intrinsic clearance in microsomes: 48 mL.min-1.g-1
The estimate for compound 4 lay 1.4-fold (0.14 log units) below the measured number; measured number inside the range.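

In this assay, this position now gives a step that can be read in full and that lies beyond the scatter: a 2.8-fold higher number from compound 3 to compound 4 (0.45 log units; beyond the scatter), with 1-benzothiophen-5-yl in place of 4-fluoropyridin-3-yl. The earlier compounds shown here offered only floors within the scatter, whereas the new comparisons clear it, with an at least 3.4-fold higher number from compound 2 to compound 4 (0.53 log units; beyond the scatter) for 1-benzothiophen-5-yl in place of methoxy and an at least 3.4-fold higher number from compound 1 to compound 4 (0.53 log units; beyond the scatter) for the same group in place of bromo. These two sizes remain floors, as compound 1 and compound 2 each carry a limit and not a number: the limit of < 14 mL.min-1.g-1 in this assay, at which 2 of the 4 values shown sit.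

1-benzothiophen-5-yl differs from 4-fluoropyridin-3-yl at once in its second ring, its sulfur and its lack of a ring nitrogen and fluorine, and the compounds shown do not separate these changes. As far as these compounds go, what a plain phenyl ring, or a pyridin-3-yl ring carrying an amine, would give at this place in this assay remains open, as does the true size of the steps from methoxy and bromo.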